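Bicyclic Amide Replacements on a Shared Core: Compound 4

The source may hold more compounds than are shown below. What is called first, only, known or untested is meant among the compounds shown, and "the series" means these compounds.

Measured compounds:
- compound 1 `CN1[C@@H]2c3[nH]c4ccccc4c3C[C@H]1[C@H](C#N)N1[C@@H](CNC(=O)c3ccc(F)cc3)c3[nH]c4ccccc4c3C[C@@H]21`: 980 nM
- compound 2 `CN1[C@@H]2c3[nH]c4ccccc4c3C[C@H]1[C@H](C#N)N1[C@@H](CNC(=O)c3cccc4c3CCCC4)c3[nH]c4ccccc4c3C[C@@H]21`: 4470 nM
- compound 3 `CN1[C@@H]2c3[nH]c4ccccc4c3C[C@H]1[C@H](C#N)N1[C@@H](CNC(=O)c3ccc4ccccc4c3)c3[nH]c4ccccc4c3C[C@@H]21`: 4650 nM

In a functional assay on MCF7 cells (Homo sapiens) for cytotoxicity, read by MTT assay, with a stated time of 72 h (a higher number here means a weaker inhibitor, a lower number a stronger inhibitor), compound 1 gives the lowest number of the three measured compounds; the nearest of the others is compound 2, and the furthest is compound 3, both of them beyond the scatter. The step to compound 4 `CN1[C@@H]2c3[nH]c4ccccc4c3C[C@H]1[C@H](C#N)N1[C@@H](CNC(=O)c3cc4ccccc4[nH]3)c3[nH]c4ccccc4c3C[C@@H]21` changes the amide end of the shared core: 1H-indol-2-yl in place of 4-fluorophenyl on a carbonyl carbon.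

Among the compounds with values here, two measured steps bear on this change, since each also replaces 4-fluorophenyl on the carbonyl carbon with a two-ring group. There is a 4.6-fold higher number from compound 1 to compound 2 (0.66 log units; beyond the scatter) and a 4.7-fold higher number from compound 1 to compound 3 (0.68 log units; beyond the scatter), and between those two products a 1.0-fold higher number from compound 2 to compound 3 (0.02 log units; within the scatter). Both earlier enlargements of the amide group therefore gave a modest weakening of the same size in this assay. Within the data shown here, the group entering in compound 4 is again a two-ring group, though it carries a hydrogen-bond donor that neither earlier group had; no measured compound shows what that donor does here. On the two steps that exist, a modest weakening from compound 1 is expected, of the order of a 3.6-fold higher number from compound 1 to compound 4 (0.55 log units; beyond the scatter). Compound 4 is accordingly estimated at 3500 nM, with a range of 1200 nM to 9000 nM.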

Compound 4, half-maximal inhibitory concentration: 9780 nM
Compound 4: middle estimate off by 2.8-fold (0.45 log units), on the low side, and the stated range ends below it.
By their numbers in this assay, from the lowest: compound 1; then compounds 2 and 3 (each within the scatter of the next); then compound 4.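

In this assay the two-ring groups on this carbonyl carbon no longer sit at one level, since 1H-indol-2-yl goes further than either earlier group (a 2.1-fold higher number from compound 3 to compound 4 (0.32 log units; beyond the scatter); a 2.2-fold higher number from compound 2 to compound 4 (0.34 log units; beyond the scatter)), with both steps beyond the scatter. Of the three replacements of 4-fluorophenyl seen at this position, 1H-indol-2-yl gives the largest weakening (a 10-fold higher number from compound 1 to compound 4 (1.00 log units; beyond the scatter)), which makes compound 4 the weakest of the four compounds and leaves compound 1 the strongest, with no two-ring group going against that order. No measurement is available to explain the further loss, and it cannot be said whether the hydrogen-bond donor of the entering group is what separates compound 4 from compounds 2 and 3.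

The compounds shown leave open whether the ring nitrogen hydrogen matters, a question that benzofuran-2-yl or 1-methylindol-2-yl on the same carbonyl carbon would address. They also leave open whether the fluorine of compound 1 contributes at all, which an unsubstituted phenyl group in its place would show.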